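An Acetyl Group Carried From One Core to Another

The source may hold more compounds than are shown below. What is called first, only, known or untested is meant among the compounds shown, and "the series" means these compounds.

Compound 2 `CCC[C@@H](O)C1=C(Br)C(=C(Br)Br)OC1=O` bears a free hydroxyl on a saturated carbon of its side chain, and in a functional assay on LNCaP cells (Homo sapiens) for cytotoxicity (on this read-out higher numbers stand for an effect only at larger amounts of compound and lower numbers for an effect already at smaller amounts), compound 2 gives 6.7 ug/mL. Compound 1 `CCC[C@@H](OC(C)=O)C1=C(Br)C(=C(Br)Br)OC1=O` differs from it by acetyl in place of hydrogen on an oxygen on a saturated carbon; in this assay compound 1 gives 2.1 ug/mL. That change made a 3.2-fold lower number from compound 2 to compound 1 (0.50 log units; beyond the scatter). Compound 3 `CCC[C@@H](O)C1=C(Br)/C(=C/I)OC1=O` rests on a different core, and the difference between the two cores is not broken down here. In this assay compound 3 gives < 0.1 ug/mL, which is a limit of the assay and not a number. Compound 4 `CCC[C@@H](OC(C)=O)C1=C(Br)/C(=C/I)OC1=O` has not been measured; it differs from compound 3 by acetyl in place of hydrogen on an oxygen on a saturated carbon, the same change as between compound 2 and compound 1. The step is expected to be a step that the limit leaves unreadable from compound 3 to compound 4, resting on a 3.2-fold lower number from compound 2 to compound 1 (0.50 log units; beyond the scatter). Because compound 3 already sits at the limit of < 0.1 ug/mL in this assay, at which 1 of the 3 values shown sits, the assay may again report only a limit. Compound 4 is estimated at 0.04 ug/mL, between 0.01 ug/mL and 0.15 ug/mL.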

Compound 4, concentration for half-maximal effect: 2 ug/mL
The estimate for compound 4 lay 50-fold (1.70 log units) below the measured number; the measured number lies above the stated range.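

On the core of compound 3, acetyl in place of hydrogen on an oxygen on a saturated carbon gave an at least 20-fold higher number from compound 3 to compound 4 (1.30 log units; beyond the scatter) in this assay, so the step seen on the core of compound 2 did not carry over, in either direction or size: the same change on two cores in this assay, a 3.2-fold lower number (0.50 log units; beyond the scatter) from compound 2 to compound 1 and an at least 20-fold higher number (1.30 log units; beyond the scatter) from compound 3 to compound 4, at least 63-fold (1.80 log units) apart, beyond the scatter of two such steps. Compound 3 gives < 0.1 ug/mL, which is a limit of the assay and not a number, so its step is bounded on one side only: the limit of < 0.1 ug/mL in this assay, at which 1 of the 4 values shown sits. The two steps show that in this series the change cannot be read from one of these cores to the other, but they do not show why, or how it would behave on any further core.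

The compounds shown leave open which part of the difference between the two cores sets the steps apart. They also leave open how a benzoyl group on that oxygen, or a longer chain on the saturated carbon, would behave on either core.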